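A methoxy group added to compound 1

This account rests on a few compounds, and the source may have more. Where it says the series, first, only, none or still open, it means among the compounds named here.

Measured compounds:
Compound 1 `Cc1ccc(Cn2c(/C=C3\SC(=S)N(CC(=O)O)C3=O)nc3ccccc32)cc1`: 1280 nM
Compound 2 `O=C(O)CN1C(=O)/C(=C/c2nc3ccccc3n2Cc2cccc(F)c2)SC1=S`: > 50000 nM (a limit of the assay)
Compound 3 `COc1ccc2c(c1)nc(/C=C1\SC(=S)N(CC(=O)O)C1=O)n2Cc1ccc(C)cc1`: 1820 nM

Among the measured compounds shown here, in a functional assay on HeLa cells (Homo sapiens) for cytotoxicity, read by MTT assay, with a stated time of 48 h (on this read-out higher numbers stand for weaker inhibition and lower numbers for stronger inhibition), compound 1 holds one of only two numbers. Its nearest neighbour is compound 3, and the third value is a limit.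

Compound 4 `COc1ccc2nc(/C=C3\SC(=S)N(CC(=O)O)C3=O)n(Cc3ccc(C)cc3)c2c1` has not yet been measured. It differs from compound 1 by a single change, methoxy in place of hydrogen on an aromatic carbon of a six-membered aromatic ring of carbon only, part of a fused or bridged system of two rings.

Two measured steps can be weighed. The closer one leads to compound 3, which carries the same kind of change, methoxy in place of hydrogen on an aromatic carbon. That step is a 1.4-fold higher number from compound 1 to compound 3 (0.15 log units; within the scatter). The other step, an at least 39-fold higher number from compound 1 to compound 2 (1.59 log units; beyond the scatter), is large, but it exchanges 4-methylphenyl for 3-fluorophenyl, and compound 4 keeps the 4-methylphenyl group. It therefore offers little guidance here.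

For the measured compounds named here, on the single comparable step, no change beyond the scatter is expected in this assay, in either direction. The estimated step is a 1.4-fold higher number from compound 1 to compound 4 (0.15 log units; within the scatter). Compound 4 is expected at about 1800 nM, within an estimated range from 700 nM to 5000 nM.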

Compound 4, half-maximal inhibitory concentration: 6440 nM
Estimate against measurement, compound 4: 3.6-fold (0.55 log units) below; measured number above the stated range.
By their numbers in this assay, from the lowest: compounds 1 and 3 (each within the scatter of the next); then compound 4. At a limit, above all of these: compound 2.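

The result shows that in this assay the effect of a methoxy group depends on where it stands on the six-membered aromatic ring of carbon only. On this aromatic carbon, meta to a fused ring and para to a fused ring, the change gives a 5.0-fold higher number from compound 1 to compound 4 (0.70 log units; beyond the scatter), whereas the same kind of change on a different aromatic carbon of that ring gave a 1.4-fold higher number from compound 1 to compound 3 (0.15 log units; within the scatter). Nothing shown here gives a reason for this dependence on place.

The compounds shown leave open whether a hydroxy group, an ethoxy group or a chlorine atom on this same aromatic carbon would raise the number as methoxy does, or whether the step belongs to methoxy alone. They also leave open how methoxy on this carbon would read with the 3-fluorophenyl group of compound 2, whose own value in this assay is only a limit.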